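Working notes: from compound 2 to compound 3

A few compounds are considered here, and "the series" means these few. Any claim that something is new, unique, unknown or untested is made for them only; others in the source may bear on it.

Values in an ADME assay on HeLa cells (Homo sapiens) for cytotoxicity, read by MTT assay; on this read-out higher numbers stand for weaker inhibition and lower numbers for stronger inhibition:
- compound 1 `CCN1CCN(C(=O)CCC(=O)Oc2ccc(C[C@H]3C(=O)OC[C@@H]3Cc3ccc(OC)c(OC)c3)cc2OC)CC1` gives 190000 nM
- compound 2 `COC(=O)[C@@H](NC(=O)CCC(=O)Oc1ccc(C[C@H]2C(=O)OC[C@@H]2Cc2ccc(OC)c(OC)c2)cc1OC)C(C)C` gives 64000 nM

Compound 2 stands at 64000 nM, the lower of the two numbers in this assay, and its gap to compound 1 is beyond the scatter. The next structure is compound 3 `COC(=O)[C@@H](NC(=O)CCC(=O)Oc1ccc(C[C@H]2C(=O)OC[C@@H]2Cc2ccc(OC)c(OC)c2)cc1OC)c1c[nH]c2ccccc12`, which differs from compound 2 in one group: 1H-indol-3-yl in place of isopropyl on a saturated chain carbon bound to an amide-type nitrogen and a carbonyl carbon. This places 1H-indol-3-yl in place of isopropyl on a saturated chain carbon bound to an amide-type nitrogen and a carbonyl carbon.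

Among the measured compounds shown here, only one measured step is available: a 3.0-fold lower number from compound 1 to compound 2 (0.47 log units; beyond the scatter). It is modest, and it concerns a different change, on a carbonyl carbon, so it offers a guide to size but only weak evidence on direction. For the measured compounds named here, no measured step covers the saturated chain carbon itself. A further modest step toward a lower number is therefore expected, with little confidence, and a result within the scatter would not surprise. For compound 3 the expected value is 35000 nM, with an estimated range of 12000 nM to 100000 nM. The estimate amounts to a 1.8-fold lower number from compound 2 to compound 3 (0.26 log units; within the scatter).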

Compound 3, half-maximal inhibitory concentration: >= 600000 nM
Compound 3: only a limit was reported; the forecaster's own chance of this, stated with the estimate: 5%; middle value at least 17-fold (1.23 log units) from the limit.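

In this assay, among the compounds shown here, the saturated chain carbon bound to an amide-type nitrogen and a carbonyl carbon responds strongly to the group it carries: 1H-indol-3-yl in place of isopropyl gives an at least 9.3-fold higher number from compound 2 to compound 3 (0.97 log units; beyond the scatter), which runs opposite in direction to the only earlier step, a 3.0-fold lower number from compound 1 to compound 2 (0.47 log units; beyond the scatter), a change on a carbonyl carbon. Compound 3 gives >= 600000 nM, which is a limit of the assay and not a number, so the full size of the new step stays unfixed. The series thus holds its first sign that a change at this place goes with weaker inhibition in this assay, with the reading for the indole compound resting on a limit: the limit of >= 600000 nM in this assay, at which 1 of the 3 values shown sits.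

A single pair cannot separate the contribution of the two aromatic rings from that of the ring nitrogen with its hydrogen-bond donor, and a phenyl group or an n-butyl chain on the same carbon would help to tell these apart. Going by these compounds, it also remains open whether the step would hold with a carboxylic acid in place of the methoxycarbonyl group.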